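Hydrogen for methyl on the aromatic ring of compound 1

This account rests on a few compounds, and the source may have more. Where it says the series, first, only, none or still open, it means among the compounds named here.

In an ADME assay on microsomes from liver (Mus musculus) for metabolic stability, read by LC-MS, with NADPH named in the record, with a stated time of 60 min, tested at 1 uM, in the absence of a further agent (a higher number here means that more of the compound is left, a lower number that less of the compound is left), compound 1 (`COc1ccc(-c2c(C)nc3c(N4CC[C@@H](NC(C)=O)C4)cc(C)nn23)cc1OC`) gives > 95% as a limit of the assay and not a number. Compound 2 (`COc1ccc(-c2c(C)nc3c(N4CCCC4)cc(C)nn23)cc1OC`) gives > 95% as a limit of the assay as well. Compound 3 (`COc1ccc(-c2c(C)nc3c(N4CC[C@@H](n5cc(-c6ccccc6)nn5)C4)cc(C)nn23)cc1OC`) is recorded as "unstable" (no number reported) with no number. Compound 1 therefore stands at the limit of > 95% in this assay, at which 2 of the 3 values shown sit, and has no exact value.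

The change to compound 4 (`COc1ccc(-c2c(C)nc3c(N4CC[C@@H](NC(C)=O)C4)ccnn23)cc1OC`) is hydrogen in place of methyl on an aromatic carbon and amounts to hydrogen in place of methyl on an aromatic carbon. Among the compounds with values here, the only measured step is a step that the two limits leave unreadable from compound 1 to compound 2 and it lies on a saturated ring carbon, so it offers no size to carry over. The estimated step of a number at least 2 percentage points lower from compound 1 to compound 4 (that floor lies within the scatter) in this assay is expected to stay within the scatter, with no direction. From the compounds shown here alone, compound 3 at "unstable" (no number reported) shows that not every member of the series matches compound 1, so the expected range stays open downward. The estimated value for compound 4 is 93% within an expected range of 75% to 100% for the percent remaining.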

Compound 4, percent of the compound remaining: > 95%
Compound 4 ended at the assay's limit (the forecaster's own chance of this, stated with the estimate: 50%); at least 2 percentage points between middle value and limit.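

In this assay, compound 1 and compound 4 both sit at the assay's limit, so no step can be read between them. The compounds shown leave open whether hydrogen in place of methyl changes the percent remaining at all: neither compound carries an exact value.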